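Fluorinated phenoxy replacements for the biphenyl ether

The source may report more compounds than this note shows. Statements on the series, on what has been measured and on what is new or still open speak of the compounds shown alone.

Compound 1 `CC(C)[C@H](NC(=O)COc1cccc2ccccc12)C(=O)N[C@@H](CC(=O)O)C(=O)COc1ccc(-c2ccccc2)cc1` carries a 4-phenylphenyl on an oxygen on a saturated carbon, and in a functional assay on Jurkat cells (Homo sapiens) (a higher number here means a weaker inhibitor, a lower number a stronger inhibitor), compound 1 gives 87900 nM. Compound 3 `CC(C)[C@H](NC(=O)COc1cccc2ccccc12)C(=O)N[C@@H](CC(=O)O)C(=O)COc1ccc(F)c(F)c1F` gives 35800 nM in this assay. Compound 2 `CC(C)[C@H](NC(=O)COc1cccc2ccccc12)C(=O)N[C@@H](CC(=O)O)C(=O)COc1ccc(F)c(F)c1` reaches only the limit of this assay, > 100000 nM, a limit and not a number (the limit of > 100000 nM in this assay, at which 1 of the 3 values shown sits). Among the two numbers shown compound 1 stands highest, with compound 3 nearest at a 2.5-fold lower number from compound 1 to compound 3 (0.39 log units; beyond the scatter).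

Compound 4 `CC(C)[C@H](NC(=O)COc1cccc2ccccc12)C(=O)N[C@@H](CC(=O)O)C(=O)COc1c(F)c(F)cc(F)c1F` is compound 1 with 2,3,5,6-tetrafluorophenyl in place of 4-phenylphenyl on an oxygen on a saturated carbon. For the measured compounds named here, three measured steps bear on this change: an at least 1.1-fold higher number from compound 1 to compound 2 (0.05 log units; that floor lies within the scatter), a 2.5-fold lower number from compound 1 to compound 3 (0.39 log units; beyond the scatter) and an at least 2.7-fold lower number from compound 2 to compound 3 (0.44 log units; beyond the scatter). The closest comparison is the step to compound 3, where a polyfluorinated phenyl in place of the 4-phenylphenyl gave a modest gain, while compound 2 shows that a lesser degree of fluorination can fall to the limit. A modest step downward is therefore expected for compound 4, about a 2.2-fold lower number from compound 1 to compound 4 (0.34 log units; beyond the scatter), with compound 2 marking the risk of a limit instead. Compound 4 is estimated at 40000 nM, within 15000 nM to 100000 nM.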

Compound 4, half-maximal inhibitory concentration: 4500 nM
Compound 4: the middle estimate sits 8.9-fold (0.95 log units) above what was measured; the measured number lies below the stated range.
By their numbers in this assay, from the lowest: compound 4; then compound 3; then compound 1. At a limit, above all of these: compound 2.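

In this assay, for the compounds shown here, 2,3,5,6-tetrafluorophenyl on an oxygen on a saturated carbon gives a 20-fold lower number from compound 1 to compound 4 (1.29 log units; beyond the scatter), and it also outdoes the 2,3,4-trifluorophenyl of the previous best with an 8.0-fold lower number from compound 3 to compound 4 (0.90 log units; beyond the scatter), so this place can carry far more gain than the earlier compounds showed. Compound 2 stands at a limit and not a number: the limit of > 100000 nM in this assay, at which 1 of the 4 values shown sits. The step to the tetrafluorophenyl, an at least 22-fold lower number from compound 2 to compound 4 (1.34 log units; beyond the scatter), is therefore only a floor.

No measured property among the compounds shown accounts for the gain. From the compounds shown here alone, whether pentafluorophenyl, or a chloro or methoxy group on the same phenyl, keeps or extends the gain stays open, as does the separate weight of fluorine count and fluorine pattern, which change together in these compounds.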